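This account rests on a few compounds, and the source may have more. Where it says the series, first, only, none or still open, it means among the compounds named here.

Measured so far in a functional assay on the whole organism for inhibition, with Rattus norvegicus as the target, read by paw edema; on this read-out higher numbers stand for an effect only at larger amounts of compound and lower numbers for an effect already at smaller amounts:
compound 1 `O=C(O)c1cc(-n2ccnc2)ccc1O` gives 75 mg/kg;
compound 2 `O=C(O)c1cc(-c2cscn2)ccc1O` gives 95 mg/kg;
compound 3 `O=C(O)c1ccc(-c2ncco2)cc1O` reaches only a limit of the assay, > 250 mg/kg.

Compound 1 holds the lowest of the two numbers, and compound 2 lies within the scatter of it, a 1.3-fold higher number from compound 1 to compound 2 (0.10 log units; within the scatter). Compound 4 `O=C(O)c1cc(-c2ncc[nH]2)ccc1O` differs from compound 1 by 1H-imidazol-2-yl in place of 1H-imidazol-1-yl on an aromatic carbon. Going by the values given here, no measured step exchanges one imidazolyl for another; the one step available, a 1.3-fold higher number from compound 1 to compound 2 (0.10 log units; within the scatter), exchanges one azole for another on the same aromatic carbon and stays within the scatter. Compound 3 contributes only the limit of > 250 mg/kg in this assay, at which 1 of the 3 values shown sits, and gives no direction. A step of the same kind is therefore expected to stay within the scatter in this assay. For compound 4 the estimate is 90 mg/kg, expected between 40 mg/kg and 200 mg/kg. This means an expected step of a 1.2-fold higher number from compound 1 to compound 4 (0.08 log units; within the scatter).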

Compound 4, dose for half-maximal effect: 200 mg/kg
Compound 4: the middle estimate sits 2.2-fold (0.35 log units) below what was measured, within the range that was stated.
By their numbers in this assay, from the lowest: compounds 1 and 2 (each within the scatter of the next); then compound 4. At a limit, above all of these: compound 3.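

On the aromatic carbon meta to a carboxy group and para to a hydroxy group, the same atoms joined differently are not interchangeable in this assay: 1H-imidazol-2-yl in place of 1H-imidazol-1-yl gives a 2.7-fold higher number from compound 1 to compound 4 (0.43 log units; beyond the scatter), a modest step. 1H-imidazol-2-yl in place of 1,3-thiazol-4-yl gives a 2.1-fold higher number from compound 2 to compound 4 (0.32 log units; beyond the scatter), also modest. Azole exchange at this place is therefore not always silent, as the first step alone suggested.

From the compounds shown here alone, how an amine or a methoxy group at this place would read remains open. Nothing available accounts for the size of these steps.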